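Methyl for cyano on the shared aryl ring

This account rests on a few compounds, and the source may have more. Where it says the series, first, only, none or still open, it means among the compounds named here.

Compound 1 `Cc1cc(C#N)cc(C)c1Oc1ccnc(Nc2ccc(C#N)cc2)n1` and compound 2 `Cc1cc(C)c(Oc2ccnc(Nc3ccc(C#N)cc3)n2)c(C)c1` share one core; compound 3 `Cc1cc(C#N)cc(C)c1Nc1nc(Nc2ccc(C#N)cc2)ncc1C#N` and compound 4 `Cc1cc(C)c(Nc2nc(Nc3ccc(C#N)cc3)ncc2C#N)c(C)c1` share another. The difference between the two cores is not broken down here. In a physicochemical assay for lipophilicity (a lower number here means a more polar compound, a higher number a more lipophilic compound), compound 1 gives 1.64, and compound 2 gives 2.07. The change between them, (methyl in place of cyano on an aromatic carbon), moved the number a number 0.43 log units higher from compound 1 to compound 2 (beyond the scatter). In this assay compound 3 gives 1.31, the lowest of the three measured numbers. Compound 4 has not yet been measured in this assay. It carries the same change from compound 3 as compound 2 carries from compound 1: methyl in place of cyano on an aromatic carbon, at the same place on the ring, so this change occurs twice in all among these compounds. For the measured compounds named here, for compound 4 the expected step is a number 0.43 log units higher from compound 3 to compound 4 (beyond the scatter), resting on the single measured pair, which gave a number 0.43 log units higher from compound 1 to compound 2 (beyond the scatter). Compound 4 is estimated at 1.74 in this assay, with a range from 1.45 to 2.05 allowing for the scatter.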

Compound 4, partition coefficient: 1.74
For compound 4 middle estimate and measured number coincide at the digits printed; the range from low to high includes it.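

In this assay, for the compounds shown here, the change of methyl in place of cyano on an aromatic carbon gives a number 0.43 log units higher from compound 3 to compound 4 (beyond the scatter) on one core and a number 0.43 log units higher from compound 1 to compound 2 (beyond the scatter) on the other, so the step has the same size and direction in both pairs and carries across these two cores with no pair going against it. This rests on just two pairs, so it does not show that the step would hold on any further core, and it says nothing about the difference between the two cores or about any other kind of measurement. Nothing at hand bears on why the step has this size.

The compounds shown hold only methyl or cyano at this place on the ring, so it remains open how an amine, a carboxylic acid or a longer chain there would read in this assay on either core. Also open, on these data alone, is whether the same change at another place on the ring would give a step of this size.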